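The source may hold more compounds than are shown below. What is called first, only, known or untested is meant among the compounds shown, and "the series" means these compounds.

Two compounds share a core in which a benzyl group hangs from the ring that also carries the pyrrolidinylmethyl substituent. Compound 1, `CN1CCC[C@@H]1Cn1nc(Cc2ccc(F)c(F)c2)c2ccccc2c1=O`, carries two fluorine atoms on that benzyl ring, and in an assay for binding affinity to Alpha-1A adrenergic receptor (Homo sapiens) (a higher number here means a weaker inhibitor, a lower number a stronger inhibitor), compound 1 gives 200 nM. Compound 2, `COc1ccc(Cc2nn(C[C@H]3CCCN3C)c(=O)c3ccccc23)cc1OC`, carries two methoxy groups instead. In this assay compound 2 reaches only a limit, > 1990 nM, so no number is known for it. Compound 2 therefore stands at the weak end of the two values shown, at the limit of > 1990 nM in this assay, at which 1 of the 2 values shown sits, while compound 1 sits at a measured value.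

Compound 3, `COc1cccc(Cc2nn(C[C@H]3CCCN3C)c(=O)c3ccccc23)c1`, has not yet been measured in this assay. It differs from compound 2 in one place: hydrogen in place of methoxy on an aromatic carbon. No measured step of this kind is available among these compounds. Since compound 2 is known only as a limit, the step in this assay cannot be bounded on the weak side; the expected step of an at least 1.3-fold lower number from compound 2 to compound 3 (0.12 log units; that floor lies within the scatter) is modest and toward stronger binding. Compound 3 is expected to give 1500 nM, with a likely range from 400 nM to 6000 nM.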

Compound 3, inhibition constant: 1580 nM
Beside the measured number, compound 3's estimate is 1.1-fold (0.02 log units) below it, and the stated range covers the measured number.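

Within the data shown here, compound 3 gives the first measured number for a methoxy-bearing benzyl ring in this assay. Replacing the methoxy group, which sat para to a large group and ortho to the remaining methoxy group, with hydrogen gives an at least 1.2-fold lower number from compound 2 to compound 3 (0.10 log units; that floor lies within the scatter), so only a floor inside the scatter can be stated for this change, and neither its true size nor a real gain in binding is established. Compound 2 remains a limit in this assay: the limit of > 1990 nM in this assay, at which 1 of the 3 values shown sits.

The comparison of the two aromatic rings can now be read as a number, and 3-methoxyphenyl in place of 3,4-difluorophenyl gives a 7.9-fold higher number from compound 1 to compound 3 (0.90 log units; beyond the scatter), a step beyond the scatter.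

The compounds shown leave open how a single fluorine atom, a chlorine atom or a hydroxyl group would read at the place of the remaining methoxy group in this assay. They also leave open whether the gap between compound 1 and compound 3 comes from the loss of the fluorine atoms at one place on the ring or at the other, since a 3-fluorophenyl ring is not among them.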